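The compounds below may be only part of what the source reports. "The series", "measured", "known", "first", "only" and "open" are said of these compounds alone.

Three compounds built on the same core, a bis(trifluoromethyl)phenyl sulfonamide joined through a saturated chain to an amine bearing an aromatic group, have been tested in a functional assay on BXPC-3 cells (Homo sapiens) for inhibition, read by MTT assay, with a stated time of 72 h; a lower number here means a stronger inhibitor of growth, a higher number a weaker inhibitor of growth. Compound 1, `O=S(=O)(NCCCNCc1cccc2ccccc12)c1cc(C(F)(F)F)cc(C(F)(F)F)c1`, gives 2700 nM in this assay. Compound 2, `CC(C)(C)c1ccc(CNCCNS(=O)(=O)c2cc(C(F)(F)F)cc(C(F)(F)F)c2)cc1`, gives 8800 nM. Compound 3, `O=S(=O)(NCCCCNCc1ccc(Br)cc1)c1cc(C(F)(F)F)cc(C(F)(F)F)c1`, gives 1700 nM, the lowest of the three numbers; the gap to compound 1 lies within the usual scatter of this assay, so the two cannot be ranked, while the gap to compound 2 lies beyond it.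

Compound 4, `O=S(=O)(NCCCNCc1ccc(Cl)cc1)c1cc(C(F)(F)F)cc(C(F)(F)F)c1`, has not yet been measured. It differs from compound 3 in one place: (4-chlorobenzyl)amino in place of ((4-bromobenzyl)amino)methyl on a saturated chain carbon, three bonds along the chain from a sulfonamide nitrogen. Going by the values given here, no pair of measured compounds that differ in exactly one place is available here, so the size of this step cannot be read from any measured pair.

Looking only at the values of compounds 1, 2 and 3, a small step upward in number from compound 3 to compound 4 seems the most likely outcome, with a 1.5-fold higher number from compound 3 to compound 4 (0.17 log units; within the scatter) expected and probably not beyond the scatter. Compound 4 is therefore estimated at 2500 nM, with a range from 1200 nM to 6000 nM, in this assay.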

Compound 4, concentration for 50% growth inhibition: 1600 nM
The estimate for compound 4 lay 1.6-fold (0.19 log units) above the measured number; the measured number falls inside the stated range.
By their numbers in this assay, from the lowest: compounds 4, 3 and 1 (each within the scatter of the next); then compound 2.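

In this assay, (4-chlorobenzyl)amino in place of ((4-bromobenzyl)amino)methyl on a saturated chain carbon, three bonds along the chain from a sulfonamide nitrogen, gives a 1.1-fold lower number from compound 3 to compound 4 (0.03 log units; within the scatter), so this change leaves no difference that can be read, even though the group that leaves carries one more carbon and bromine instead of chlorine. The second step, 4-chlorophenyl in place of naphthalen-1-yl on a saturated chain carbon bound to an amine nitrogen, gives a 1.7-fold lower number from compound 1 to compound 4 (0.23 log units; within the scatter), so among these compounds the aromatic group can also change without a readable shift in the number. Nothing measured here accounts for how small these two steps are.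

Steps involving compound 2 cannot be read, since it differs from each of the other compounds in more than one place. Also open, on these data alone, is what exchanging bromine for chlorine does with the chain held fixed, and whether a nitrile or a carboxylic acid in place of the halogen would keep the number within the scatter of compound 4 in this assay.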